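Solubility on a Shared Core: Compounds 1 to 4

This account rests on a few compounds, and the source may have more. Where it says the series, first, only, none or still open, it means among the compounds named here.

Measured compounds:
compound 1, `CC(C)Cc1ccc2c(NCCCNCc3ccco3)ccnc2c1`: 4200 nM
compound 2, `c1coc(CNCCCNc2ccnc3cc(CC4CCCCC4)ccc23)c1`: 4200 nM
compound 3, `c1coc(CNCCCNc2ccnc3cc(C4CCCCC4)ccc23)c1`: 4200 nM

In a physicochemical assay for solubility, with a stated time of 18 h, at pH 7.4 (a lower number here means a less soluble compound, a higher number a more soluble compound), compound 3 stands level with compound 1 and compound 2. The steps of no change at the digits printed from compound 1 to compound 2 (within the scatter), no change at the digits printed from compound 1 to compound 3 (within the scatter) and no change at the digits printed from compound 2 to compound 3 (within the scatter) all lie within the scatter, so none of the three changes moved solubility. Compound 4, `Clc1ccc(Oc2ccc3c(NCCCNCc4ccco4)ccnc3c2)cc1`, differs from compound 3 by 4-chlorophenoxy in place of cyclohexyl on an aromatic carbon. Within the data shown here, no measured step exchanges a saturated ring for an aromatic one carrying an acceptor, so the bearing of the earlier steps is indirect. Since every change so far left the value unmoved, compound 4 is expected to show no change at the digits printed from compound 3 to compound 4 (within the scatter). The estimate for compound 4 is 4200 nM, within 1400 nM to 13000 nM.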

Compound 4, solubility: 14500 nM
Beside the measured number, compound 4's estimate is 3.5-fold (0.54 log units) below it, and the stated range ends below it.
By their numbers in this assay, from the lowest: compounds 1, 2 and 3 (each within the scatter of the next); then compound 4.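

In this assay the position on the aromatic carbon turns out to respond, since 4-chlorophenoxy in place of cyclohexyl gives a 3.5-fold higher number from compound 3 to compound 4 (0.54 log units; beyond the scatter) on the shared core. The entering group also gives a 3.5-fold higher number from compound 2 to compound 4 (0.54 log units; beyond the scatter) in place of cyclohexylmethyl and a 3.5-fold higher number from compound 1 to compound 4 (0.54 log units; beyond the scatter) in place of isobutyl, so the change of the group, not just of one partner, separates compound 4 from the three level compounds. No available measurement accounts for this rise.

Which part of the entering group carries the rise stays open: the oxygen, the aromatic ring or the chlorine. Phenoxy and cyclohexyloxy at this place would separate these.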